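This account rests on a few compounds, and the source may have more. Where it says the series, first, only, none or still open, it means among the compounds named here.

Measured so far:
Compound 1, `CN(c1ccccc1)S(=O)(=O)c1ccc(NC(=O)c2ccc(Cl)cc2Cl)cc1`: 50%
Compound 2, `O=C(Nc1ccc(S(=O)(=O)Nc2ccccc2)cc1)c1ccc(Cl)cc1Cl`: 100%

In a functional assay on HEK293 cells for agonist activity at probable G-protein coupled receptor 27 (Homo sapiens), read by a luciferase reporter and beta-arrestin recruitment, with a stated time of 10 min (a lower number here means a smaller maximal response, a higher number a larger maximal response), compound 2 gives 100%, the higher of the two numbers. Its nearest neighbour is compound 1, which in this assay gives 50%; the step between them, a number 50 percentage points higher from compound 1 to compound 2 (beyond the scatter), came from putting hydrogen in place of methyl on a sulfonamide nitrogen.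

Compound 3, `O=C(Nc1ccc(S(=O)(=O)Nc2ccccc2Cl)cc1)c1ccc(Cl)cc1Cl`, differs from compound 2 in one place: chloro in place of hydrogen on an aromatic carbon. For the measured compounds named here, the only measured step, a number 50 percentage points higher from compound 1 to compound 2 (beyond the scatter), concerns the sulfonamide nitrogen and not the aromatic ring, so it does not bear on this change, and no measured pair shows what a chloro in this position does. With compound 2 as the only anchor, the expectation is a change of no more than moderate size in this assay, if any, and the estimated step is a number 15 percentage points lower from compound 2 to compound 3 (beyond the scatter). For compound 3 the expected value is 85%, with a range from 50% to 110%.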

Compound 3, largest response reached (Emax), in percent of the reference or control that the assay uses: 53%
Beside the measured number, compound 3's estimate is 32 percentage points above it; the measured number falls inside the stated range.
By their numbers in this assay, from the lowest: compounds 1 and 3 (each within the scatter of the next); then compound 2.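

In this assay, going from phenyl to 2-chlorophenyl is far from a neutral edit: one chloro ortho to a large group gives a number 47 percentage points lower from compound 2 to compound 3 (beyond the scatter), so the maximal response depends on what sits on this aromatic carbon. Two edits in different places, the chloro here and the methyl on the sulfonamide nitrogen, leave compounds that cannot be told apart, with a number 3 percentage points higher from compound 1 to compound 3 (within the scatter), and of these three compounds only compound 2, which carries neither group, reaches the higher response. Nothing available explains this drop.

As far as these compounds go, it remains open whether the loss is specific to chloro or would also follow from another group on the same carbon, such as fluoro or methoxy. Also open, from the compounds shown here alone, is how a chloro would behave at another carbon of that ring.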